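A few compounds are considered here, and "the series" means these few. Any claim that something is new, unique, unknown or untested is made for them only; others in the source may bear on it.

Measured compounds:
compound 1 `Oc1nc2nonc2nc1Nc1ccc(OC(F)(F)F)c(Cl)c1`: 3000 nM
compound 2 `Oc1nc2nonc2nc1Nc1ccc(C(F)(F)F)c(F)c1`: 11600 nM

Both were tested in an assay on mitochondria from L6 cells (Rattus norvegicus) for activation, with a stated time of 90 min; a lower number here means that less compound is needed, a higher number that more compound is needed for the effect. Of the two numbers, compound 2 has the higher one at 11600 nM, whereas compound 1 comes in at 3000 nM, a gap that lies beyond the usual scatter of repeated measurements.

Compound 3 `Oc1nc2nonc2nc1Nc1ccc(OC(F)(F)F)c(F)c1` has not yet been measured. It differs from compound 2 in one place: trifluoromethoxy in place of trifluoromethyl on an aromatic carbon. The fluoro group is kept, and the shared core stays the same.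

Compound 1 carries the same trifluoromethoxy group, paired with chloro, and gives 3000 nM, the lower of the two numbers. Among the compounds with values here, on that basis a modest drop is expected for compound 3, with a step of a 2.1-fold lower number from compound 2 to compound 3 (0.32 log units; beyond the scatter), although no measured pair here isolates this exchange alone, so the size is uncertain. The estimate for compound 3 in this assay is 5500 nM, expected to fall between 2000 nM and 14000 nM.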

Compound 3, half-maximal effective concentration: 2900 nM
Compound 3: the middle estimate sits 1.9-fold (0.28 log units) above what was measured, and the stated range covers the measured number.
By their numbers in this assay, from the lowest: compounds 3 and 1 (each within the scatter of the next); then compound 2.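

In this assay, the exchange of trifluoromethyl for trifluoromethoxy can now be read on its own, with the fluoro group kept: the change gives a 4.0-fold lower number from compound 2 to compound 3 (0.60 log units; beyond the scatter), a step beyond the usual scatter. The exchange of chloro for fluoro, with trifluoromethoxy kept, gives a 1.0-fold lower number from compound 1 to compound 3 (0.01 log units; within the scatter), which lies within the scatter, so this pair does not separate the two halogens. No measured property available here explains either step.

From the compounds shown here alone, it remains open whether the step seen on exchanging trifluoromethyl for trifluoromethoxy would be similar with chloro in place of fluoro. Going by these compounds, how a methoxy group, a nitrile or an amine would compare at the same aromatic carbon in this assay also remains open.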